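This account rests on a few compounds, and the source may have more. Where it says the series, first, only, none or still open, it means among the compounds named here.

Compound 1 `COc1ccc(Nc2cc(C)nc(Nc3ccc(NS(=O)(=O)c4ccccc4Cl)cc3)n2)cc1`: > 50000 nM
Compound 2 `COc1ccc(Nc2cc(C)nc(Nc3ccc(NS(=O)(=O)c4c(Cl)cc(C)cc4OC)cc3)n2)cc1`: > 50000 nM
Compound 3 `COc1cc(Nc2ccnc(Nc3ccc(NS(=O)(=O)c4ccc(C)cc4)cc3)n2)cc(OC)c1OC`: > 50000 nM

The value of compound 1 is a limit of the assay, not a measured number. So is the value of compound 2. So is the value of compound 3. In a functional assay on MCF7 cells (Homo sapiens) for antiproliferative activity, read by MTT assay (on this read-out higher numbers stand for weaker inhibition and lower numbers for stronger inhibition), compound 1 therefore stands at the limit of > 50000 nM in this assay, at which 3 of the 3 values shown sit, with no exact figure known. The step that the two limits leave unreadable from compound 1 to compound 2 is unreadable for the same reason. Compound 4 `COc1ccc(Nc2ccc(Nc3nc(C)cc(Nc4ccc(OC)cc4)n3)cc2)cc1` differs from compound 1 by 4-methoxyphenyl in place of (2-chlorophenyl)sulfonyl on a nitrogen on an aromatic ring. Within the data shown here, the only measured step is unreadable, so it gives no guidance on the size or direction of this change. Compound 4 is expected to show an at least 1.2-fold lower number from compound 1 to compound 4 (0.09 log units; that floor lies within the scatter), and it may well end again at the limit. The estimate for compound 4 is 40000 nM, within 8000 nM to 50000 nM.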

Compound 4, half-maximal inhibitory concentration: > 50000 nM
Compound 4: no number, only a limit (the forecaster's own chance of this, stated with the estimate: 70%); at least 1.2-fold (0.09 log units) between middle value and limit.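

Compound 1 and compound 4 both sit at a limit rather than a measured number, so the step between them cannot be read: the limit of > 50000 nM in this assay, at which 4 of the 4 values shown sit.

The compounds shown leave open whether any single change to them would give a true number in this assay.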